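Dropping the Ethyl from the Pyrrole Ring

The source may hold more compounds than are shown below. What is called first, only, known or untested is meant among the compounds shown, and "the series" means these compounds.

Compound 1 `CC(=O)N[C@@H]1c2cc(C#N)ccc2OC(C)(C)[C@H]1O` gives 2900 nM in a functional assay (Trachealis) for inhibition, with Cavia porcellus as the target; a lower number here means a stronger inhibitor, a higher number a weaker inhibitor. Compound 2 `CCc1cccn1C1=CC(C)(C)Oc2ccc(C#N)cc21`, tested in this assay, yields only a limit of the assay, > 20000 nM, and no number. Compound 2 therefore stands at the limit of > 20000 nM in this assay, at which 1 of the 2 values shown sits. Compound 3 `CC1(C)C=C(n2cccc2)c2cc(C#N)ccc2O1` differs from it by hydrogen in place of ethyl on an aromatic carbon. Among the measured compounds shown here, no measured pair shows this change. Because compound 2 rests at the limit of > 20000 nM in this assay, at which 1 of the 2 values shown sits, compound 3 is expected to remain weak, with a step that the limit leaves unreadable from compound 2 to compound 3 amounting to no step beyond the scatter. Compound 3 is estimated at 30000 nM, within 8000 nM to 100000 nM.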

Compound 3, half-maximal inhibitory concentration: 4080 nM
For compound 3 the middle estimate is 7.4-fold (0.87 log units) above the measured one; measured number outside the range, below it.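

The change from 2-ethyl-1H-pyrrol-1-yl to 1H-pyrrol-1-yl gives, in this assay, an at least 4.9-fold lower number from compound 2 to compound 3 (0.69 log units; beyond the scatter). This shows that the aromatic carbon next to the ring nitrogen responds to what it carries, and that the pyrrole without ethyl gives a real number. The full size of the step stays unknown, since its starting point is a limit held by compound 2: the limit of > 20000 nM in this assay, at which 1 of the 3 values shown sits.

The compounds shown leave open how a methyl, a methoxy or an amine at this carbon would read. They also leave open whether ethyl on the other ring carbons would behave alike.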